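Working notes: stripping the aryl group from compound 2

This account rests on a few compounds, and the source may have more. Where it says the series, first, only, none or still open, it means among the compounds named here.

Of the compounds shown here, two have been measured so far in a functional assay on HepG2 cells (Homo sapiens) for antiproliferative activity, read by MTT assay, with a stated time of 72 h; a lower number here means a stronger inhibitor, a higher number a weaker inhibitor. Compound 1 `O=C1COc2ccc(-c3cnc(Cl)c(NS(=O)(=O)c4ccc(F)cc4)c3)cc2N1C1CCCCC1` gives > 40000 nM, which is a limit of the assay and not a number. Within the data shown here, compound 2 `COc1cccc(N2C(=O)COc3ccc(-c4cnc5ccccc5c4)cc32)c1` gives 2080 nM, the only actual number.

The next compound is compound 3 `O=C1COc2ccc(-c3cnc4ccccc4c3)cc2N1`, which carries hydrogen in place of 3-methoxyphenyl on an amide-type nitrogen in a ring. Among the measured compounds shown here, no pair of measured compounds differs in one place only, so the size of this step rests on judgement alone. A weakening in this assay beyond the usual scatter is expected, starting from compound 2 at 2080 nM, as the whole 3-methoxyphenyl group is lost and the rest of the structure stays the same. The estimated step is a 5.8-fold higher number from compound 2 to compound 3 (0.76 log units; beyond the scatter). The estimate for compound 3 is 12000 nM, with an expected range of 3500 nM to 40000 nM.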

Compound 3, half-maximal inhibitory concentration: 26300 nM
Beside the measured number, compound 3's estimate is 2.2-fold (0.34 log units) below it; the range from low to high includes it.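

In this assay, among these compounds, the first step that can be read is the loss of 3-methoxyphenyl from the amide-type nitrogen in the ring, a 13-fold higher number from compound 2 to compound 3 (1.10 log units; beyond the scatter), and since the rest of the structure is unchanged, the whole of this step belongs to that one position. The substituent on this nitrogen therefore matters for the antiproliferative read-out, at least in the pair at hand, although compound 3, with only hydrogen there, still gives a measured number, 26300 nM. Compound 1 gives a limit of the assay and not a number, and it differs from the others in more than one place, so no step to it can be read: the limit of > 40000 nM in this assay, at which 1 of the 3 values shown sits.

The pair does not separate the aromatic ring of 3-methoxyphenyl from its methoxy group, as the two leave together; a plain phenyl group on the same nitrogen would divide the step between them. Going by these compounds, how little is needed at this position also stays open, and a methyl group or an ethyl group there would test whether a small alkyl chain recovers any of the loss.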